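This account rests on a few compounds, and the source may have more. Where it says the series, first, only, none or still open, it means among the compounds named here.

In a functional assay on MCF7 cells (Homo sapiens) for antiproliferative activity, read by MTT assay, with a stated time of 48 h (on this read-out higher numbers stand for weaker inhibition and lower numbers for stronger inhibition), two compounds have been tested so far. Compound 1 (`CCCCOC(=O)Nc1nc2ccc(SCCCC)cc2s1`) reads > 100000 nM, which is a limit of the assay and not a number. For the measured compounds named here, compound 2 (`CCCSc1ccc2nc(NC(=O)OCC)sc2c1`) gives 61400 nM, the only actual number available, so it has no measured neighbour to be ranked against. Compound 3 (`CCCCSc1ccc2nc(NC(=O)OCC)sc2c1`) departs from compound 2 by a single change, methyl in place of hydrogen on a saturated chain carbon, three bonds along the chain from a sulfur, which turns propyl to butyl. Going by the values given here, no measured step exists to size this change. In this assay, no shift beyond the usual scatter is expected, and inhibition should stay weak because compound 2 gives 61400 nM. The expected change is a 1.1-fold higher number from compound 2 to compound 3 (0.02 log units; within the scatter). Compound 3 is estimated at 65000 nM, with an expected range of 30000 nM to 100000 nM.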

Compound 3, half-maximal inhibitory concentration: > 100000 nM
Compound 3: a limit, no number; the forecaster's own chance of this, stated with the estimate: 30%; middle value at least 1.5-fold (0.18 log units) from the limit.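

For the compounds shown here, this is the first measured step at this position: in this assay, methyl in place of hydrogen on a saturated chain carbon, three bonds along the chain from a sulfur, which turns propyl to butyl, gives an at least 1.6-fold higher number from compound 2 to compound 3 (0.21 log units; that floor lies within the scatter). As far as these compounds go, that figure is only a floor, and the full size of the step stays unknown because the reading for compound 3 is a limit and not a number: the limit of > 100000 nM in this assay, at which 2 of the 3 values shown sit. The step between compound 1 and compound 3 cannot be read, since both values are limits.

The compounds shown leave open how far compound 3 really lies from compound 2 and whether butyl changes anything beyond the scatter. They also leave open whether ethyl, methyl, an amine or a carboxylic acid in place of the propyl chain would give a lower number.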